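The compounds below may be only part of what the source reports. "The series", "measured", "known", "first", "only" and "open" are said of these compounds alone.

Compound 3 `C=CCn1ncc2c(C)ncn2c1=O` is one of three close relatives examined in a functional assay for inhibition, with Homo sapiens as the target; a lower number here means a stronger inhibitor, a higher number a weaker inhibitor. In this assay compound 3 gives only a limit, > 48000 nM. Compound 1 `C=CCn1ncc2c(C)nc(CC)n2c1=O` carries an ethyl group on an aromatic carbon, and in this assay compound 1 likewise reaches only a limit, > 48000 nM. Compound 2 `C=CCn1ncc2c(C)nc(C)n2c1=O` carries a methyl group on that aromatic carbon, and in this assay compound 2 gives 73000 nM. The steps among these three are a step that the limit leaves unreadable from compound 1 to compound 2, a step that the two limits leave unreadable from compound 1 to compound 3 and a step that the limit leaves unreadable from compound 2 to compound 3; none of them can be read because of the limit of > 48000 nM in this assay, at which 2 of the 3 values shown sit. Compound 4 `C=CCn1ncc2c(C)nc(C(C)(C)C)n2c1=O` differs from compound 3 by tert-butyl in place of hydrogen on an aromatic carbon. The steps from compound 1 to compound 3 and from compound 2 to compound 3 bear on this change, and both are unreadable. Accordingly the step from compound 3 to compound 4 is expected to be a step that the limit leaves unreadable from compound 3 to compound 4, with no direction beyond the scatter discernible. For compound 4 the estimate in this assay is 60000 nM, between 20000 nM and 200000 nM, and most likely it is again reported only as a limit.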

Compound 4, half-maximal inhibitory concentration: > 48000 nM
Compound 4 ended at the assay's limit; the forecaster's own chance of this, stated with the estimate: 65%; the middle value does not contradict the limit.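

Compound 4 also ends at a limit in this assay, so none of the steps from compound 1, compound 2 or compound 3 to compound 4 can be read: the limit of > 48000 nM in this assay, at which 3 of the 4 values shown sit.

The compounds shown leave open whether hydrogen, methyl, ethyl and tert-butyl on that aromatic carbon differ at all in this assay.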